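Second methoxy on the aryl ketone of the piperazine series

The source may report more compounds than this note shows. Statements on the series, on what has been measured and on what is new or still open speak of the compounds shown alone.

Measured so far in an ADME assay on Vero cells (Chlorocebus sabaeus) for cytotoxicity, read by resazurin assay, with a stated time of 72 h; a higher number here means a weaker inhibitor, a lower number a stronger inhibitor:
compound 1 `O=C(CCN1CCN(c2ccc(C(F)(F)F)cc2)CC1)c1ccccc1` gives 15700 nM
compound 2 `Cc1ccc(C(=O)CCN2CCN(c3ccc(C(F)(F)F)cc3)CC2)cc1` gives 140000 nM
compound 3 `COc1ccc(C(=O)CCN2CCN(c3ccc(C(F)(F)F)cc3)CC2)cc1` gives 135000 nM

Compound 3 stands second highest of the three numbers. Its nearest neighbour is compound 2, and the two values lie within the scatter of each other, so no order between them is claimed. The gap to compound 1 is the step of an 8.6-fold higher number from compound 1 to compound 3 (0.93 log units; beyond the scatter), which is beyond the scatter.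

The next compound is compound 4 `COc1ccc(C(=O)CCN2CCN(c3ccc(C(F)(F)F)cc3)CC2)cc1OC`. The change from compound 3 is methoxy in place of hydrogen on an aromatic carbon, the second methoxy entering ortho to a methoxy group, so that 4-methoxyphenyl becomes 3,4-dimethoxyphenyl.

Going by the values given here, two measured steps bear on this: an 8.6-fold higher number from compound 1 to compound 3 (0.93 log units; beyond the scatter) and an 8.9-fold higher number from compound 1 to compound 2 (0.95 log units; beyond the scatter), each a single small group entering the same aromatic ring and each moving the number up by a modest amount. Whether a second such group moves it further is not shown by the data. The expectation in this assay is therefore a small upward step or none beyond the scatter, the step being estimated as a 1.5-fold higher number from compound 3 to compound 4 (0.17 log units; within the scatter). Compound 4 is thus estimated at 200000 nM, within the range 80000 nM to 500000 nM.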

Compound 4, half-maximal inhibitory concentration: 243000 nM
Estimate against measurement, compound 4: 1.2-fold (0.08 log units) below; the range from low to high includes it.
By their numbers in this assay, from the lowest: compound 1; then compounds 3, 2 and 4 (each within the scatter of the next).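

In this assay, the second methoxy, entering ortho to a methoxy group, gives a step that stays within the scatter (a 1.8-fold higher number from compound 3 to compound 4 (0.26 log units; within the scatter)), so at this position no separate contribution of the added group can be read from the number. The comparison with the 4-methylphenyl ketone also stays within the scatter (a 1.7-fold higher number from compound 2 to compound 4 (0.24 log units; within the scatter)), and no order is claimed among compound 2, compound 3 and compound 4, which now form one cluster of three substituted aryl ketones. Only the comparison with the phenyl ketone lies beyond the scatter, and it is a large step (a 15-fold higher number from compound 1 to compound 4 (1.19 log units; beyond the scatter)), so the one separation in this set remains that between compound 1 and the substituted compounds, while no evidence is available here to account for any of these steps.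

On these data alone, it remains open whether the upward step from phenyl holds only for methyl and methoxy or also for an amine or a carboxylic acid on the same ring. As far as these compounds go, the effect of a longer chain between the carbonyl and the rest of the shared core is also open.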